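The source may report more compounds than this note shows. Statements on the series, on what has been measured and on what is new or still open speak of the compounds shown alone.

Among the compounds with values here, compound 1, `CCOC(=O)C12C(=O)OCC=C1COC2c1ccccc1`, was tested in a functional assay on HeLa cells (Homo sapiens) for cytotoxicity, read by MTT assay (a lower number here means a stronger inhibitor, a higher number a weaker inhibitor), where compound 1 gives 12800 nM, the lowest of the three numbers measured so far, though the other two lie within the scatter of it. Compound 2, `CCOC(=O)C12C(=O)OCC=C1COC2c1ccc(OC)cc1`, carries a methoxy in place of hydrogen on an aromatic carbon and gives 18300 nM in this assay; the step of a 1.4-fold higher number from compound 1 to compound 2 (0.16 log units; within the scatter) stays within the scatter. Compound 3, `CCOC(=O)C12C(=O)OCC=C1COC2c1ccc(N(C)C)cc1`, carries a dimethylamino on an aromatic carbon and gives 23400 nM; the steps of a 1.8-fold higher number from compound 1 to compound 3 (0.26 log units; within the scatter) and a 1.3-fold higher number from compound 2 to compound 3 (0.11 log units; within the scatter) also stay within the scatter. Compound 4, `CCOC(=O)C12C(=O)OCC=C1COC2c1ccccn1`, differs from compound 1 by pyridin-2-yl in place of phenyl on a saturated ring carbon. Within the data shown here, no measured step swaps one aromatic ring for another, but both measured steps change the same ring and neither moves this assay beyond the scatter, so a step of similar size is expected here, with no direction claimed. Compound 4 is therefore expected to give 14000 nM in this assay, with a range from 6000 nM to 35000 nM. The estimated step is a 1.1-fold higher number from compound 1 to compound 4 (0.04 log units; within the scatter).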

Compound 4, half-maximal inhibitory concentration: 20700 nM
Compound 4: the middle estimate sits 1.5-fold (0.17 log units) below what was measured; measured number inside the range.
By their numbers in this assay, from the lowest: compounds 1, 2, 4 and 3 (each within the scatter of the next).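

Compounds 2 and 3 changed only a group on the aromatic ring, whereas compound 4 alters the ring itself: pyridin-2-yl brings a ring nitrogen, counted as a hydrogen-bond acceptor, to the saturated ring carbon. In this assay the exchange gives a 1.6-fold higher number from compound 1 to compound 4 (0.21 log units; within the scatter), so this first change to the ring itself cannot be told apart from repeat-measurement noise, and a single ring nitrogen at this place leaves the number as unresolved from compound 1 as the two earlier groups did. No measurement here bears on why the number falls where it does.

Going by these compounds, whether pyridin-3-yl, pyridin-4-yl or a saturated cyclohexyl in place of phenyl would move the number beyond the scatter remains open. Also open, on these data alone, is what a carboxylic acid in place of the ethoxycarbonyl group would do.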